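Ether series: allyl in place of dimethoxybenzyl

A few compounds are considered here, and "the series" means these few. Any claim that something is new, unique, unknown or untested is made for them only; others in the source may bear on it.

Compound 1 `CCOC(=O)CCO/N=C(/c1ccc(OC)c(OC)c1OC)c1cccc2ccccc12` gives 10000 nM in a functional assay on HCT-116 cells (Homo sapiens) for inhibition, read by sulforhodamine B assay, with a stated time of 48 h; on this read-out higher numbers stand for weaker inhibition and lower numbers for stronger inhibition. Compound 3 `COc1ccc(/C(=N/O)c2cccc3ccccc23)c(OC)c1OC` gives 5880 nM in this assay. Between these two neighbours the step of a 1.7-fold lower number from compound 1 to compound 3 (0.23 log units; within the scatter) is the only measured one in the series so far. Compound 2 `COc1cc(COC(c2ccc(OC)c(OC)c2OC)c2cccc3ccccc23)cc(OC)c1` is reported in this assay only as the limit > 20000 nM. That value is the assay limit of > 20000 nM in this assay, at which 1 of the 3 values shown sits, and not a number, so compound 2 stands at the weak end of what has been seen without a measured position of its own.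

Compound 4 `C=CCOC(c1ccc(OC)c(OC)c1OC)c1cccc2ccccc12` has not yet been measured in this assay. It differs from compound 2 by vinyl in place of 3,5-dimethoxyphenyl on a saturated chain carbon bound to an oxygen on a saturated carbon. The measured step of a 1.7-fold lower number from compound 1 to compound 3 (0.23 log units; within the scatter) concerns a different place in the molecule and lies within the scatter, so it offers no direct guide to this change. With compound 2 at a limit, the expected step of an at least 1.4-fold lower number from compound 2 to compound 4 (0.15 log units; that floor lies within the scatter) can only be set loosely. Compound 4 is estimated to give about 14000 nM in this assay, within a range from 4000 nM to 30000 nM.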

Compound 4, half-maximal inhibitory concentration: > 20000 nM
Compound 4 ended at the assay's limit; the forecaster's own chance of this, stated with the estimate: 40%; at least 1.4-fold (0.15 log units) between middle value and limit.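

Among these compounds, compound 2 and compound 4 both stand at a limit rather than at a number, so no step between them can be read: the limit of > 20000 nM in this assay, at which 2 of the 4 values shown sit.

The compounds shown leave open whether vinyl in place of 3,5-dimethoxyphenyl changes inhibition in this assay at all, and in which direction.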